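The compounds below may be only part of what the source reports. "The series", "measured", "known", "first", "only" and "open" are said of these compounds alone.

Of the compounds shown here, three from one series have been measured in a functional assay for antagonist activity at transient receptor potential cation channel subfamily V member 1 (Rattus norvegicus); on this read-out lower numbers stand for stronger inhibition and higher numbers for weaker inhibition. Compound 1 `CC(C)(C)c1ccc(NC(=O)c2ccc(-c3ncccc3C#N)cc2)cc1` gives 13 nM, compound 2 `CCCNc1cccnc1-c1ccc(C(=O)Nc2ccc(C(C)(C)C)cc2)cc1` gives 37 nM, and compound 3 `CC(C)(C)c1ccc(NC(=O)c2ccc(-c3ncccc3C(=O)O)cc2)cc1` gives 560 nM, the highest of the three numbers, set apart from compound 2 by a 15-fold higher number from compound 2 to compound 3 (1.18 log units; beyond the scatter) and from compound 1 by a 43-fold higher number from compound 1 to compound 3 (1.63 log units; beyond the scatter). Compound 4 `CC(C)(C)c1ccc(NC(=O)c2ccc(-c3ncccc3-c3nn[nH]n3)cc2)cc1` is not yet measured; it differs from compound 3 in that (2H-tetrazol-5-yl in place of carboxy on an aromatic carbon). Both measured steps ending in compound 3 show that carboxy at this site goes with a much higher number than cyano or propylamino. A new group at the same site is therefore expected to move the number of compound 4 part of the way back, by a 2.8-fold lower number from compound 3 to compound 4 (0.45 log units; beyond the scatter), to an estimated 200 nM within 50 nM to 800 nM.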

Compound 4, half-maximal inhibitory concentration: > 4000 nM
Compound 4 ended at the assay's limit; the forecaster's own chance of this, stated with the estimate: 5%; middle value at least 20-fold (1.30 log units) away from the limit.
By their numbers in this assay, from the lowest: compound 1; then compound 2; then compound 3. At a limit, above all of these: compound 4.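

In this assay compound 4 gives a limit and not a number: the limit of > 4000 nM in this assay, at which 1 of the 4 values shown sits. So carboxy was not the poorest group at this position, since 2H-tetrazol-5-yl in its place gives an at least 7.1-fold higher number from compound 3 to compound 4 (0.85 log units; beyond the scatter). The gap to the other groups also widens, with an at least 100-fold higher number from compound 2 to compound 4 (2.03 log units; beyond the scatter) and an at least 300-fold higher number from compound 1 to compound 4 (2.48 log units; beyond the scatter), so propylamino and cyano both go with far lower numbers here than this five-membered ring.

Going by these compounds, how far compound 4 really lies past the limit stays unknown. Also open, on these data alone, is whether a primary amide or a hydroxymethyl group at this site would stay nearer cyano or fall with carboxy.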